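Amino group on the shared core: two nucleoside pairs

The source may report more compounds than this note shows. Statements on the series, on what has been measured and on what is new or still open speak of the compounds shown alone.

All numbers below come from a functional assay on K562 cells (Homo sapiens), read by MTT assay, with a stated time of 72 h; a higher number here means a weaker inhibitor, a lower number a stronger inhibitor.

Compound 1 `COc1ncnc2c1c(-c1cccs1)cn2[C@@H]1O[C@H](CO)[C@@H](O)[C@H]1O`: 6200 nM
Compound 2 `COc1nc(N)nc2c1c(-c1cccs1)cn2[C@@H]1O[C@H](CO)[C@@H](O)[C@H]1O`: > 20000 nM, a limit of the assay, not a number
Compound 3 `O=c1[nH]cnc2c1c(-c1ccco1)cn2[C@@H]1O[C@H](CO)[C@@H](O)[C@H]1O`: 17800 nM

Compound 4 `Nc1nc2c(c(-c3ccco3)cn2[C@@H]2O[C@H](CO)[C@@H](O)[C@H]2O)c(=O)[nH]1` is not yet measured in this assay.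

Among the measured compounds, compound 3 gives the highest number, with compound 1 nearest. For compound 2 only a limit is available, as noted in the limit of > 20000 nM in this assay, at which 1 of the 3 values shown sits.

One change occurs twice in this set. From compound 1 to compound 2 it is amino in place of hydrogen on an aromatic carbon, and this step gave an at least 3.2-fold higher number from compound 1 to compound 2 (0.50 log units; beyond the scatter). From compound 3 to compound 4 the change is amino in place of hydrogen on an aromatic carbon. The two place descriptions differ only in the group to which the new amino is meta: a methoxy group (2 heavy atoms) on the core of compound 1, a group of 1 heavy atom on the core of compound 3. It is therefore the same kind of change, not the same change. The difference between the two cores is not broken down here.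

Resting on the step from compound 1 to compound 2, the expectation for compound 4 is a step of about a 2.8-fold higher number from compound 3 to compound 4 (0.45 log units; beyond the scatter) in this assay, since the earlier step was at least modest and started from a lower number. Compound 4 is thus estimated at 50000 nM, within a range of 20000 nM to 150000 nM, and a limit rather than a number is expected more often than not.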

Compound 4, half-maximal inhibitory concentration: > 20000 nM
Compound 4 was reported as a limit; the forecaster's own chance of this, stated with the estimate: 75%; the middle value is on the limit's open side.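

In this assay, amino in place of hydrogen on an aromatic carbon on the core of compound 3 gives an at least 1.1-fold higher number from compound 3 to compound 4 (0.05 log units; that floor lies within the scatter) and the floor of that step does not by itself establish a rise. Set beside the earlier step, the result does not separate the two cores: the same change on two cores in this assay, an at least 3.2-fold higher number (0.50 log units; beyond the scatter) from compound 1 to compound 2 and an at least 1.1-fold higher number (0.05 log units; that floor lies within the scatter) from compound 3 to compound 4; the limit leaves it open whether they differ. Compound 4 is reported only as a limit, as is compound 2, so the series is consistent with the change carrying over from one core to the other but does not show that it does, nor how large the step is on either core, and neither of these compounds gives an exact number: the limit of > 20000 nM in this assay, at which 2 of the 4 values shown sit.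

The compounds shown leave open the true size of the amino step on each core, and whether the gap between the core of compound 1 and the core of compound 3 alters that step at all. They also leave open how a methylamino group or a chlorine atom on the same aromatic carbon would read in this assay on either core, so nothing here fixes whether the outcome is specific to amino.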